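Vinyl in Place of 3-Chloropropyl on Two Amide Cores

The source may report more compounds than this note shows. Statements on the series, on what has been measured and on what is new or still open speak of the compounds shown alone.

Two amides carry the same change at their carbonyl carbon. Compound 1 `CC(C)(C)c1ccc(CNC(=O)CCCCl)cc1` bears the 3-chloropropyl group, and in a functional assay on MCF7 cells (Homo sapiens) for antiproliferative activity, with a stated time of 48 h (on this read-out higher numbers stand for weaker inhibition and lower numbers for stronger inhibition), compound 1 gives 92000 nM. Compound 3 `C=CC(=O)NCc1ccc(C(C)(C)C)cc1` differs from it by vinyl in place of 3-chloropropyl on a carbonyl carbon. In this assay compound 3 reaches only the limit of the assay, > 100000 nM. The step of an at least 1.0-fold higher number from compound 1 to compound 3 (0.03 log units; that floor lies within the scatter) is thus bounded on one side only; what can be said of it rests on (the limit of > 100000 nM in this assay, at which 2 of the 3 values shown sit).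

Compound 2 `CCCCC(O)c1cccc(NC(=O)CCCCl)c1` stands on another core; the difference between the two cores is not broken down here. In this assay compound 2 gives only the limit, > 100000 nM. Compound 4 `C=CC(=O)Nc1cccc(C(O)CCCC)c1` is the unmeasured partner of compound 2 and differs from it by vinyl in place of 3-chloropropyl on a carbonyl carbon, the same change as that from compound 1 to compound 3, at a place described in the same words.

Given the step of an at least 1.0-fold higher number from compound 1 to compound 3 (0.03 log units; that floor lies within the scatter), compound 4 is expected to give 150000 nM. The expected step that the limit leaves unreadable from compound 2 to compound 4 is therefore small and most likely unresolved. For compound 4 the estimated range runs from 70000 nM to 400000 nM.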

Compound 4, half-maximal inhibitory concentration: > 100000 nM
Compound 4 was reported as a limit; the forecaster's own chance of this, stated with the estimate: 80%; the middle value does not contradict the limit.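

In this assay compound 4 is reported only as a limit, > 100000 nM. Compound 2 is also reported only as a limit, so no step can be read between compound 2 and compound 4: the limit of > 100000 nM in this assay, at which 3 of the 4 values shown sit.

The compounds shown leave open whether vinyl in place of 3-chloropropyl on a carbonyl carbon changes antiproliferative activity on either core.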